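From Bromo to Methyl on Compound 1

The source may report more compounds than this note shows. Statements on the series, on what has been measured and on what is new or still open speak of the compounds shown alone.

In a functional assay on HepG2 cells (Homo sapiens) for inhibition, read by MTT assay, with a stated time of 48 h (a higher number here means a weaker inhibitor, a lower number a stronger inhibitor), compound 1 `O=C(C=CNc1cc(-c2ccccc2)nn1-c1ccccc1)c1ccc(Br)cc1` gives 8810 nM, the lowest of the three numbers available. Compound 3 `CN1CCN(c2ccc(-c3c(C#N)c(-c4ccc(Cl)cc4)nc4c3c(-c3ccccc3)nn4-c3ccccc3)cc2)CC1` gives 14600 nM, which lies within the scatter of the value for compound 1, so the two cannot be separated. Compound 2 `Clc1ccc(-c2ccnc3c2c(-c2ccccc2)nn3-c2ccccc2)cc1` gives 61100 nM, a weaker reading that lies beyond the scatter from compound 1.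

Compound 4 `Cc1ccc(C(=O)C=CNc2cc(-c3ccccc3)nn2-c2ccccc2)cc1` keeps the rest of compound 1 and changes one place: methyl in place of bromo on an aromatic carbon. This puts methyl in place of bromo on an aromatic carbon, para to a large group. For the measured compounds named here, no measured pair here shows what such an exchange does, so the expectation rests only on the single-atom size of the change. No step beyond the scatter is expected in this assay, with at most a slight drift toward a higher number. The expected change is a 1.2-fold higher number from compound 1 to compound 4 (0.10 log units; within the scatter). For compound 4 the estimated value is 11000 nM, with an expected range of 3500 nM to 30000 nM.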

Compound 4, half-maximal inhibitory concentration: 7320 nM
For compound 4 the middle estimate is 1.5-fold (0.18 log units) above the measured one; measured number inside the range.
By their numbers in this assay, from the lowest: compounds 4, 1 and 3 (each within the scatter of the next); then compound 2.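

In this assay the exchange of bromo for methyl gives a 1.2-fold lower number from compound 1 to compound 4 (0.08 log units; within the scatter) and this step lies within the scatter, so the two compounds cannot be separated. This is the first pair shown that differs in one place, and it indicates that, on this aromatic carbon para to a large group, methyl and bromo read alike in this assay. No measured evidence bears on why the two groups read alike.

The compounds shown leave open whether an amine, a carboxylic acid or a longer chain on the same aromatic carbon would move the number beyond the scatter. With only bromo and methyl compared at this position, they also leave open how far this position can be changed before the reading shifts.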